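A few compounds are considered here, and "the series" means these few. Any claim that something is new, unique, unknown or untested is made for them only; others in the source may bear on it.

The measured compounds are:

- compound 1 `Nc1scc(CN2CCN(c3cccc(Cl)c3Cl)CC2)c1C(=O)c1ccc(Cl)cc1`: 2%
- compound 2 `Nc1scc(CN2CCN(c3ccc(Cl)cc3F)CC2)c1C(=O)c1ccc(Cl)cc1`: 0%
- compound 3 `Nc1scc(CN2CCN(c3ccc(F)cc3F)CC2)c1C(=O)c1ccc(Cl)cc1`: 1%

All three were tested in an assay on CHO cells for displacement of a labelled ligand from adenosine receptor A1 (Homo sapiens), read by scintillation counting, with a stated time of 120 min, tested at 10 uM; on this read-out higher numbers stand for more inhibition at the one concentration tested (going by the name of the read-out) and lower numbers for less inhibition. Compound 2 sits among the others without separation: the step of a number 2 percentage points lower from compound 1 to compound 2 (within the scatter) and the step of a number 1 percentage points higher from compound 2 to compound 3 (within the scatter) are both within the scatter, as is a number 1 percentage points lower from compound 1 to compound 3 (within the scatter). On these numbers compound 2 is not set apart from compound 1 or compound 3.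

The unmeasured compound 4 `Nc1scc(CN2CCN(c3cc(F)ccc3F)CC2)c1C(=O)c1ccc(Cl)cc1` differs from compound 2 in one place:

2,5-difluorophenyl in place of 4-chloro-2-fluorophenyl on an amine nitrogen in a ring

Every measured step concerns the same position, the aryl group on the amine nitrogen of the ring, and each swaps halogen patterns on that phenyl: a number 2 percentage points lower from compound 1 to compound 2 (within the scatter), a number 1 percentage points lower from compound 1 to compound 3 (within the scatter) and a number 1 percentage points higher from compound 2 to compound 3 (within the scatter). None of them leaves the scatter, and the figures for compound 1, compound 2 and compound 3 are all close to zero. The change from compound 2 to compound 4 is of the same kind, so no step beyond the scatter is expected in this assay in either direction.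

Compound 4 is therefore expected to give about 1% in this assay, between -5% and 8%, an expected step of a number 1 percentage points higher from compound 2 to compound 4 (within the scatter).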

Compound 4, a percentage reported as inhibition, at one concentration (the size of the read-out at that concentration, not a potency): 1%
Estimate against measurement, compound 4: no gap at the digits printed; measured number inside the range.
By their numbers in this assay, from the lowest: compounds 2, 3, 4 and 1 (each within the scatter of the next).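

In this assay, the 2,5-difluorophenyl group on the amine nitrogen in a ring leaves the number in the same narrow band as the other halogen patterns, with a number 1 percentage points higher from compound 2 to compound 4 (within the scatter) and a number 1 percentage points lower from compound 1 to compound 4 (within the scatter) as its steps from the chlorine-bearing aryl groups. For the compounds shown here, what the earlier compounds did not show is a change in fluorine placement alone: the 2,4-difluorophenyl and 2,5-difluorophenyl groups carry the same atoms, and the step between them is no change at the digits printed from compound 3 to compound 4 (within the scatter), so this rearrangement separates nothing here, just as the exchanges of chlorine for fluorine separated nothing before it. Nothing available explains why these four aryl groups are not told apart in this read-out.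

As far as these compounds go, whether a methoxy group, an amine or a carboxylic acid on this phenyl, or a benzyl group in its place, would lift the number clear of the scatter remains open. Also open is whether changes to the shared core outside this aryl group would move the read-out, since the four compounds shown differ only at this one position.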